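An ethyl group added to compound 2

A few compounds are considered here, and "the series" means these few. Any claim that something is new, unique, unknown or untested is made for them only; others in the source may bear on it.

In a functional assay on HCT-116 cells (Homo sapiens) for cytotoxicity, read by MTT assay, with a stated time of 48 h (on this read-out higher numbers stand for weaker inhibition of growth and lower numbers for stronger inhibition of growth), two compounds have values so far:
Compound 1 (`Nc1ccccc1Cn1c(C(F)(F)F)nc2cc(Cl)c(Cl)cc21`): 26100 nM
Compound 2 (`Clc1cc2ncn(C3CCCC3)c2cc1Cl`): 37000 nM

Among the compounds with values here, compound 1 at 26100 nM and compound 2 at 37000 nM lie within the usual scatter of each other, so compound 2 cannot be ranked against the only other number available. Compound 3 (`CCc1nc2cc(Cl)c(Cl)cc2n1C1CCCC1`) is compound 2 with ethyl in place of hydrogen on an aromatic carbon, and it has not yet been measured. Within the data shown here, no measured pair shows this change on its own, so the data offer no direct guide to its size. In this assay no step beyond the scatter is expected, with a slight lean toward stronger inhibition of growth. The expected move is an estimated 1.5-fold lower number from compound 2 to compound 3 (0.17 log units; within the scatter) that stays within the scatter. The estimate for compound 3 is an expected 25000 nM (range 10000 nM to 60000 nM).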

Compound 3, concentration for 50% growth inhibition: 38000 nM
Beside the measured number, compound 3's estimate is 1.5-fold (0.18 log units) below it; low and high end bracket the measured number.
By their numbers in this assay, from the lowest: compounds 1, 2 and 3 (each within the scatter of the next).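

In this assay, ethyl in place of hydrogen on the aromatic carbon between two ring nitrogen atoms gives a 1.0-fold higher number from compound 2 to compound 3 (0.01 log units; within the scatter). Within the data shown here, this is the first pair that differs in one place, and it shows that, on the shared core with its cyclopentyl group, hydrogen and ethyl at this position cannot be told apart on this read-out. Nothing available explains this result.

The compounds shown leave open whether this position would stay as undiscriminating with a larger or differently charged group, such as a phenyl ring, an amine or a carboxylic acid. They also leave open whether ethyl would give a similar result if the cyclopentyl group were replaced by another group, such as a cyclohexyl ring.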